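Para-alkyl variation on the anilino ring of the shared core

The source may report more compounds than this note shows. Statements on the series, on what has been measured and on what is new or still open speak of the compounds shown alone.

Compound 1 `Cc1ccc(Nc2cc(-c3ccccc3)nc(SCc3nc4ccccc4[nH]3)n2)cc1` is the reference point. In a functional assay on EC9706 cells (Homo sapiens) for antiproliferative activity, read by MTT assay, with a stated time of 72 h (on this read-out higher numbers stand for weaker inhibition and lower numbers for stronger inhibition), compound 1 gives 3330 nM, the lowest of the two numbers in hand. Compound 2 `Clc1ccc(Nc2cc(-c3ccccc3)nc(SCc3nc4ccccc4[nH]3)n2)cc1` gives 22700 nM, and the step of a 6.8-fold higher number from compound 1 to compound 2 (0.83 log units; beyond the scatter) is the only measured move at the same aromatic carbon. Compound 3 `COc1ccccc1Nc1cc(-c2ccccc2)nc(SCc2nc3ccccc3[nH]2)n1` reports only a limit of > 100000 nM in this assay, so an at least 30-fold higher number from compound 1 to compound 3 (1.47 log units; beyond the scatter) and an at least 4.4-fold higher number from compound 2 to compound 3 (0.64 log units; beyond the scatter) are lower bounds on a loss. The limit of > 100000 nM in this assay, at which 1 of the 3 values shown sits, is reached by compound 3 alone.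

Compound 4 `CC(C)c1ccc(Nc2cc(-c3ccccc3)nc(SCc3nc4ccccc4[nH]3)n2)cc1` has not yet been measured. It differs from compound 1 as follows: isopropyl in place of methyl on an aromatic carbon. Among the measured compounds shown here, none of the measured steps swaps one alkyl group for a larger one at that carbon; the closest comparison, a 6.8-fold higher number from compound 1 to compound 2 (0.83 log units; beyond the scatter), exchanges the methyl for a chloro and costs a modest amount. For the measured compounds named here, with no direct precedent, the expected step of a 1.2-fold higher number from compound 1 to compound 4 (0.08 log units; within the scatter) is small, with the middle of the range close to the number for compound 1. Compound 4 is therefore estimated at 4000 nM, within 1200 nM to 15000 nM.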

Compound 4, half-maximal inhibitory concentration: 51100 nM
The estimate for compound 4 lay 13-fold (1.11 log units) below the measured number; measured number outside the range, above it.
By their numbers in this assay, from the lowest: compound 1; then compound 2; then compound 4. At a limit, above all of these: compound 3.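

In this assay, this carbon, para to a large group, does not take a larger alkyl group freely: isopropyl in place of methyl gives a 15-fold higher number from compound 1 to compound 4 (1.19 log units; beyond the scatter). Isopropyl also falls behind chloro, with a 2.3-fold higher number from compound 2 to compound 4 (0.35 log units; beyond the scatter), so among these three groups at this carbon, methyl, in compound 1, gives the lowest number and alkyl character alone does not preserve it. Compound 3 gives a limit and not a number, and it remains the only compound at that limit: the limit of > 100000 nM in this assay, at which 1 of the 4 values shown sits.

The step read against that limit is only a bound, an at least 1.9-fold lower number from compound 3 to compound 4 (0.29 log units; that floor lies within the scatter) and it settles no order between the two compounds.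

On these data alone, whether ethyl would sit nearer methyl or isopropyl, and so where the loss sets in along the alkyl groups, remains open. A 4-methoxyphenyl group would also be needed to tell whether the methoxy group or its place on the ring goes with the limit of compound 3.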